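The source may report more compounds than this note shows. Statements on the series, on what has been measured and on what is new or still open speak of the compounds shown alone.

For the measured compounds named here, compound 1 `Brc1ccc(OC[C@@H]2CCN2)cn1` binds most tightly of the three compounds measured so far: in an assay on brain for binding affinity to Neuronal acetylcholine receptor; alpha4/beta2 (Rattus norvegicus), read by radioligand binding (on this read-out lower numbers stand for stronger inhibition and higher numbers for weaker inhibition), compound 1 gives 0.021 nM. Compound 2 `C=Cc1ccc(OC[C@@H]2CCN2)cn1` differs from it at a single aromatic carbon, and in this assay compound 2 gives 1.25 nM. Going by the values given here, the step of a 60-fold higher number from compound 1 to compound 2 (1.77 log units; beyond the scatter) is the only measured change available in which a halogen on the shared core is exchanged for a carbon substituent. Compound 3 `Brc1cncc(OC[C@@H]2CCN2)c1` keeps the bromo but carries it on a different carbon of the shared core; in this assay compound 3 gives 0.18 nM. That value is the second highest of the three numbers: it lies between compound 1 and compound 2, and its gap to each of them is beyond the scatter.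

Compound 4 `CCCc1cncc(OC[C@@H]2CCN2)c1` has not yet been measured. It arises from compound 3 by propyl in place of bromo on an aromatic carbon. Among the compounds with values here, the only step that bears on this change is a 60-fold higher number from compound 1 to compound 2 (1.77 log units; beyond the scatter), where bromo also gave way to a carbon chain and the number rose sharply. Propyl is a longer chain than vinyl, so a weakening of at least comparable size is expected in this assay. Compound 4 is therefore expected to give about 8 nM, within an expected range of 1.5 nM to 45 nM. This estimate corresponds to an expected step of a 44-fold higher number from compound 3 to compound 4 (1.65 log units; beyond the scatter).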

Compound 4, inhibition constant: 0.039 nM
Compound 4: middle estimate off by 210-fold (2.31 log units), on the high side; the measured number lies below the stated range.
By their numbers in this assay, from the lowest: compounds 1 and 4 (each within the scatter of the next); then compound 3; then compound 2.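

In this assay, the exchange of bromo for propyl on this aromatic carbon, two atoms from the ring nitrogen, gives a 4.6-fold lower number from compound 3 to compound 4 (0.66 log units; beyond the scatter), so at this position a carbon chain binds more tightly than bromo. The earlier step, a 60-fold higher number from compound 1 to compound 2 (1.77 log units; beyond the scatter), ran the opposite way, with vinyl entering on a different carbon of the shared core, so exchanging bromo for a carbon substituent has no single direction across the compounds shown. These two steps differ both in the entering group and in its place, and nothing offered here gives a reason for the gain seen with propyl.

On these data alone, whether vinyl on this same carbon, or propyl on the carbon that carries bromo in compound 1, would follow the direction seen here stays open, so the effect of the group and the effect of its place remain tied together. Also open, as far as these compounds go, is how this position would respond to a longer chain such as butyl, or to an amine or a carboxylic acid in place of propyl.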